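The compounds below may be only part of what the source reports. "The series", "measured", "known", "first", "only" and "open" are said of these compounds alone.

Measured compounds in an ADME assay on microsomes from liver (Homo sapiens) for metabolic stability, tested at 2.5 uM; on this read-out lower numbers stand for slow clearance and higher numbers for fast clearance:
- compound 1 `N#Cc1cccc(S(=O)(=O)c2cnc3cc(F)ccc3c2-c2ccccc2F)c1`: 1.39 mL/min
- compound 2 `O=S(=O)(c1ccc(F)c(Cl)c1)c1cnc2cc(F)ccc2c1-c1ccccc1F`: 1.07 mL/min
- compound 3 `O=S(=O)(c1ccc(F)c(F)c1)c1cnc2cc(F)ccc2c1-c1ccccc1F`: 0.79 mL/min

On these numbers compound 1 sits at the top of the three, but the step to compound 2 a 1.3-fold lower number from compound 1 to compound 2 (0.11 log units; within the scatter) and the step to compound 3 a 1.8-fold lower number from compound 1 to compound 3 (0.25 log units; within the scatter) are both within the scatter, so the three compounds are not separated by this assay. The step between the two halogenated analogues a 1.4-fold lower number from compound 2 to compound 3 (0.13 log units; within the scatter) is likewise within the scatter.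

Compound 4 `N#Cc1cccc(S(=O)(=O)c2cnc3cc(F)ccc3c2-c2cccc(F)c2)c1` has not yet been measured. It differs from compound 1 as follows: 3-fluorophenyl in place of 2-fluorophenyl on an aromatic carbon. Among the measured compounds shown here, every measured step so far concerns the group on the sulfonyl sulfur; none touches the aromatic carbon where this change sits, so no measured step bears directly on it. The three steps that do exist are all within the scatter, and nothing in the data points to a larger movement for compound 4.

Compound 4 is therefore expected to give 1.4 mL/min in this assay, with a range from 0.6 mL/min to 3.2 mL/min. The expected step of a 1.0-fold higher number from compound 1 to compound 4 (0.00 log units; within the scatter) is estimated to lie within the scatter.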

Compound 4, intrinsic clearance in a liver preparation (reported as CLH), per the amount of preparation that the assay uses: 0.78 mL/min
Compound 4: the middle estimate sits 1.8-fold (0.25 log units) above what was measured, and the stated range covers the measured number.
By their numbers in this assay, from the lowest: compounds 4, 3, 2 and 1 (each within the scatter of the next).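

Among the compounds shown here, this is the first measured change at this aromatic carbon: with 3-fluorophenyl in place of 2-fluorophenyl and the same atoms joined differently, this assay gives a 1.8-fold lower number from compound 1 to compound 4 (0.25 log units; within the scatter). Moving the fluorine on this ring therefore does not separate the two compounds, and the same holds for the changes on the sulfonyl sulfur, so no position in the series has yet given a step beyond the scatter. No measurement bears on the reason for the size of this step.

Still open, as far as these compounds go, is whether a different kind of group at this aromatic carbon, such as an amine or a carboxylic acid in place of the fluorophenyl, would give a step beyond the scatter. Also open, from the compounds shown here alone, is whether 3-fluorophenyl gives the same picture with 3,4-difluorophenyl or 3-chloro-4-fluorophenyl on the sulfonyl sulfur.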